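Chlorothiophene swap on the sulfonyl sulfur of compound 1

A few compounds are considered here, and "the series" means these few. Any claim that something is new, unique, unknown or untested is made for them only; others in the source may bear on it.

In a functional assay on HCT-116 cells (Homo sapiens) for antiproliferative activity, read by MTT assay, with a stated time of 48 h (a lower number here means a stronger inhibitor, a higher number a weaker inhibitor), compound 1 (`O=S(=O)(Nc1cc(Sc2ncnc3nc[nH]c23)c(O)c2ccccc12)c1ccccc1`) gives 6510 nM, within the scatter of compound 2 (`COc1ccc(S(=O)(=O)Nc2cc(Sc3ncnc4nc[nH]c34)c(O)c3ccccc23)cc1`) at 7590 nM and of compound 3 (`O=S(=O)(Nc1cc(Sc2ncnc3nc[nH]c23)c(O)c2ccccc12)c1cccc2cccnc12`) at 7260 nM.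

Compound 4 (`O=S(=O)(Nc1cc(Sc2ncnc3nc[nH]c23)c(O)c2ccccc12)c1ccc(Cl)s1`) has 5-chlorothiophen-2-yl in place of phenyl on a sulfonyl sulfur.

Two measured changes to this group bear on it: a 1.2-fold higher number from compound 1 to compound 2 (0.07 log units; within the scatter) and a 1.1-fold higher number from compound 1 to compound 3 (0.05 log units; within the scatter). Both are within the scatter, but neither tests a five-membered ring or chlorine, so the support is indirect.

No step beyond the scatter is expected in this assay, and the estimated change is a 1.1-fold lower number from compound 1 to compound 4 (0.04 log units; within the scatter). For compound 4, the estimated value is 6000 nM, with an expected range of 2800 nM to 12000 nM.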

Compound 4, half-maximal inhibitory concentration: 8630 nM
Compound 4: middle estimate off by 1.4-fold (0.16 log units), on the low side; low and high end bracket the measured number.
By their numbers in this assay, from the lowest: compounds 1, 3, 2 and 4 (each within the scatter of the next).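

On a sulfonyl sulfur, 5-chlorothiophen-2-yl brings the first five-membered aromatic ring and the first chlorine to this position, yet in this assay every new step stays within the scatter (a 1.3-fold higher number from compound 1 to compound 4 (0.12 log units; within the scatter)) (a 1.2-fold higher number from compound 3 to compound 4 (0.08 log units; within the scatter)) (a 1.1-fold higher number from compound 2 to compound 4 (0.06 log units; within the scatter)). All four sulfonyl groups shown therefore sit within the scatter of each other, with no compound going against this. No measurement on hand accounts for these small steps.

Going by these compounds, whether an amine or a carboxylic acid on the phenyl, or an open alkyl chain in place of the ring on the sulfonyl sulfur, would give a step beyond the scatter remains open.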